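Side-chain change from compound 3 to compound 4

The compounds below may be only part of what the source reports. "The series", "measured", "known", "first", "only" and "open" are said of these compounds alone.

Among the measured compounds shown here, in a functional assay on A549 cells (Homo sapiens) for cytotoxicity, read by MTT assay, with a stated time of 48 h (a higher number here means a weaker inhibitor, a lower number a stronger inhibitor), compound 3 `COc1c(OCCCCNCc2ccccc2)cc(O)c2c(=O)cc(-c3ccccc3)oc12` gives 4590 nM, the only true number in this small set. Compound 1 `CCN(CC)CCCOc1c(O)cc(O)c2c(=O)cc(-c3ccccc3)oc12` reads > 100000 nM, which is a limit. Compound 2 `CN1CCN(CCCCOc2c(O)cc(O)c3c(=O)cc(-c4ccccc4)oc23)CC1` reads > 100000 nM, also a limit. Compound 4 `COc1c(OCCCN2CCCC2)cc(O)c2c(=O)cc(-c3ccccc3)oc12` keeps the core of compound 3 and changes the side chain: pyrrolidin-1-yl in place of (benzylamino)methyl on a saturated chain carbon, three bonds along the chain from an oxygen on an aromatic ring. Cut one bond further out, this reads 3-(benzylamino)propyl to 2-(pyrrolidin-1-yl)ethyl.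

For the measured compounds named here, no measured step shows this change directly. Going by the values given here, the one step available, a step that the two limits leave unreadable from compound 1 to compound 2, has no readable size. The nearest guide is the limit of > 100000 nM in this assay, at which 2 of the 3 values shown sit. Compounds 1 and 2 both lack the benzylamino group and both sit at that limit, but their cores differ from that of compound 3, so the comparison is loose. A move towards weaker inhibition in this assay is therefore expected, of uncertain size. The estimated change is a 4.4-fold higher number from compound 3 to compound 4 (0.64 log units; beyond the scatter). For compound 4 the expected value is 20000 nM, with an estimated range of 5000 nM to 80000 nM.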

Compound 4, half-maximal inhibitory concentration: 1390 nM
For compound 4 the middle estimate is 14-fold (1.16 log units) above the measured one; measured number below the stated range.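

Replacing (benzylamino)methyl with pyrrolidin-1-yl on the side chain gives a 3.3-fold lower number from compound 3 to compound 4 (0.52 log units; beyond the scatter) in this assay. On this core, then, a measurable value does not depend on the aromatic ring or the hydrogen-bond donor of the leaving group, since the entering pyrrolidin-1-yl has neither. Among the compounds shown here, this is the first readable step, as the only earlier step joins two limits and cannot be read.

The step changes the amine and the length of the chain together, so the contribution of each stays unseparated. As far as these compounds go, how a piperidine or morpholine on the same chain, or the pyrrolidine on a longer chain, would read in this assay remains open.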